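Amine substituent notes on the shared core

The compounds below may be only part of what the source reports. "The series", "measured", "known", "first", "only" and "open" are said of these compounds alone.

compound 1, `CCCCN(CC)c1nc(C)nc2c1nnn2-c1ccc(C(C)C)cc1Br`: 7.5 nM
compound 2, `CCN(c1nc(C)nc2c1nnn2-c1ccc(C(C)C)cc1Br)C(COC)COC`: 123 nM

Within the data shown here, in an in vitro assay on 293-EBNA cells for binding affinity to corticotropin-releasing factor receptor 1 (Homo sapiens) (on this read-out higher numbers stand for weaker inhibition and lower numbers for stronger inhibition), compound 2 gives 123 nM, the highest of the two numbers so far; the nearest is compound 1, which gives 7.5 nM. Among the measured compounds shown here, the only measured step is a 16-fold higher number from compound 1 to compound 2 (1.21 log units; beyond the scatter). Compound 3, `COCCNc1nc(C)nc2c1nnn2-c1ccc(C(C)C)cc1Br`, differs from compound 2 by a group of 5 heavy atoms (3 carbon, 1 nitrogen, 1 oxygen; no ring) in place of a group of 10 heavy atoms (7 carbon, 1 nitrogen, 2 oxygen; no ring), on an aromatic carbon. For the measured compounds named here, the measured step exchanges one substituent on that nitrogen while an ethyl group is kept; the change to compound 3 removes both and leaves the (2-methoxyethyl)amino group alone, so no measured step bears on it directly, and the expectation in this assay is correspondingly loose. A step of a 1.5-fold lower number from compound 2 to compound 3 (0.19 log units; within the scatter) is estimated. Compound 3 is expected near 80 nM, in a range from 15 nM to 400 nM.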

Compound 3, inhibition constant: 242 nM
For compound 3 the middle estimate is 3.0-fold (0.48 log units) below the measured one; the measured number falls inside the stated range.
By their numbers in this assay, from the lowest: compound 1; then compounds 2 and 3 (each within the scatter of the next).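

The (2-methoxyethyl)amino group in place of the group of 10 heavy atoms gives a 2.0-fold higher number from compound 2 to compound 3 (0.29 log units; within the scatter) in this assay, so on this aromatic carbon the two amines cannot be told apart, although the hydrogen-bond donor count goes from 0 to 1. Against butyl(ethyl)amino, the same group gives a 32-fold higher number from compound 1 to compound 3 (1.51 log units; beyond the scatter), which leaves compound 1 alone at the low end and both methoxy-bearing amines together well away from it. Nothing available on these compounds accounts for that gap.

On these data alone, compound 3 differs from compound 1 in both substituents on the nitrogen at once, so the part played by the ether oxygen, the chain or the ethyl group stays open. Butylamino or ethyl(2-methoxyethyl)amino on the same carbon would help separate these.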